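This account rests on a few compounds, and the source may have more. Where it says the series, first, only, none or still open, it means among the compounds named here.

Measured compounds:
compound 1, `Cc1cn([C@@H]2O[C@H](CO[Si](C)(C)C(C)(C)C)[C@@]3(OS(=O)(=O)C=C3NCC(N)=O)[C@H]2O[Si](C)(C)C(C)(C)C)c(=O)n(C)c1=O`, in a functional assay on HEL cells (Homo sapiens) for cytotoxicity, read by microscopy (a lower number here means that less compound is tolerated, a higher number that more compound is tolerated), gives 16000 nM
compound 2, `Cc1cn([C@@H]2O[C@H](CO[Si](C)(C)C(C)(C)C)[C@@]3(OS(=O)(=O)C=C3NC(N)=O)[C@H]2O[Si](C)(C)C(C)(C)C)c(=O)n(C)c1=O`, in this assay gives 16000 nM
compound 3, `COC(=O)CC(=O)NC1=CS(=O)(=O)O[C@@]12[C@@H](CO[Si](C)(C)C(C)(C)C)O[C@@H](n1cc(C)c(=O)n(C)c1=O)[C@@H]2O[Si](C)(C)C(C)(C)C`, in this assay gives 400000 nM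

Among these three, compound 3 stands at the highest number in this assay: it is the compound of which most is tolerated. The two steps that lead to it are both large and in the same direction, a 25-fold higher number from compound 1 to compound 3 (1.40 log units; beyond the scatter) and a 25-fold higher number from compound 2 to compound 3 (1.40 log units; beyond the scatter), while between the two lower compounds no change at the digits printed from compound 1 to compound 2 (within the scatter). Compound 4, `Cc1cn([C@@H]2O[C@H](CO[Si](C)(C)C(C)(C)C)[C@@]3(OS(=O)(=O)C=C3NCCC(N)=O)[C@H]2O[Si](C)(C)C(C)(C)C)c(=O)n(C)c1=O`, is not yet measured in this assay. The change from compound 3 is 2-carbamoylethyl in place of ((methoxycarbonyl)methyl)carbonyl on an amine nitrogen. This removes the ((methoxycarbonyl)methyl)carbonyl group that alone sets compound 3 apart from compounds 1 and 2, and puts in its place a chain carrying a carbamoyl group, a close relative of the carbamoylmethyl chain of compound 1. Since the whole gap between compound 3 and compound 1 rests on this one group, a large step back toward the lower numbers is expected in this assay, namely a 20-fold lower number from compound 3 to compound 4 (1.30 log units; beyond the scatter). Compound 4 is therefore estimated at 20000 nM, with a range from 8000 nM to 64000 nM.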

Compound 4, minimum cytotoxic concentration: >= 80000 nM
Compound 4 gave a limit, no number (the forecaster's own chance of this, stated with the estimate: 5%); at least 4.0-fold (0.60 log units) between middle value and limit.
By their numbers in this assay, from the lowest: compounds 1 and 2 (each within the scatter of the next); then compound 3.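

In this assay compound 4 gives a limit and no number: the limit of >= 80000 nM in this assay, at which 1 of the 4 values shown sits. Earlier, the chain on the amine nitrogen made no difference, with no change at the digits printed from compound 1 to compound 2 (within the scatter); the 2-carbamoylethyl group now shows that a chain ending in carbamoyl can move this read-out at this position, with an at least 5.0-fold higher number from compound 1 to compound 4 (0.69 log units; beyond the scatter) and an at least 5.0-fold higher number from compound 2 to compound 4 (0.69 log units; beyond the scatter). Going by these compounds, the step from compound 3 cannot be read, so a high number no longer rests on the ((methoxycarbonyl)methyl)carbonyl group alone, though the order of those two compounds remains unknown.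

On these data alone, how far compound 4 lies beyond its limit stays open. Also open, as far as these compounds go, is whether a longer chain such as 3-carbamoylpropyl, or a chain ending in an amine or a carboxylic acid, would follow the same trend at this amine nitrogen.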